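A few compounds are considered here, and "the series" means these few. Any claim that something is new, unique, unknown or untested is made for them only; others in the source may bear on it.

Working notes on the series in an assay on CHO cells for displacement of a labelled ligand from Substance-P receptor (Homo sapiens), read by scintillation counting; a higher number here means a weaker inhibitor, a lower number a stronger inhibitor. Compound 1 `Cc1cc(F)ccc1[C@H]1C[C@@H](N2CCC2)CCN1C(=O)N(C)Cc1cc(C(F)(F)F)cc(C(F)(F)F)c1` gives 0.0813 nM. Compound 2 `Cc1cc(F)ccc1[C@H]1C[C@@H](N2CCC2)CCN1C(=O)N(C)[C@H](C)c1cc(C(F)(F)F)cc(C(F)(F)F)c1` gives 0.178 nM. Compound 3 `Cc1cc(F)ccc1[C@H]1C[C@H](N2CCC2)CCN1C(=O)N(C)[C@H](C)c1cc(C(F)(F)F)cc(C(F)(F)F)c1` gives 0.646 nM. Compound 2 thus holds the second-lowest number of the three: a 2.2-fold higher number from compound 1 to compound 2 (0.34 log units; beyond the scatter) and a 3.6-fold higher number from compound 2 to compound 3 (0.56 log units; beyond the scatter), the latter step resting on (the fact that compounds 2 and 3 differ only in the configuration as drawn). Compound 4 `Cc1cc(F)ccc1[C@H]1C[C@@H](NC2CC2)CCN1C(=O)N(C)[C@H](C)c1cc(C(F)(F)F)cc(C(F)(F)F)c1` differs from compound 2 by cyclopropylamino in place of azetidin-1-yl on a saturated ring carbon. Within the data shown here, neither measured step touches that position, so no measured step bears directly on this change; both measured steps were modest in size, and a modest step in this assay, most likely toward a somewhat higher number, is expected here too. Compound 4 is estimated at 0.32 nM, with a range from 0.08 nM to 1.3 nM. The expected step is a 1.8-fold higher number from compound 2 to compound 4 (0.25 log units; within the scatter).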

Compound 4, inhibition constant: 0.324 nM
Estimate against measurement, compound 4: 1.0-fold (0.01 log units) below, within the range that was stated.
By their numbers in this assay, from the lowest: compound 1; then compounds 2, 4 and 3 (each within the scatter of the next, the first and the last beyond it).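

At this saturated ring carbon, cyclopropylamino in place of azetidin-1-yl gives a 1.8-fold higher number from compound 2 to compound 4 (0.26 log units; within the scatter) in this assay, the only step shown that touches this substituent. The amine here can thus carry a hydrogen-bond donor, which azetidin-1-yl lacks, with no change beyond the scatter. Nothing on hand explains this result.

On these data alone, what remains open is how an open-chain dimethylamino group or a morpholin-4-yl group would read at this carbon. Also open, as far as these compounds go, is whether cyclopropylamino would read alike with this carbon in the configuration of compound 3.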